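A few compounds are considered here, and "the series" means these few. Any claim that something is new, unique, unknown or untested is made for them only; others in the source may bear on it.

Compound 1 `CCCC(CCC)n1c(-c2ccc(OCc3c(-c4c(Cl)cccc4Cl)noc3C(C)C)cc2)nc2ccc(C(=O)O)cc21` — in an assay on Huh-7 cells for agonist activity at Bile acid receptor (Homo sapiens), read by a luciferase reporter (a lower number here means that less compound is needed, a higher number that more compound is needed for the effect), compound 1 gives 1.8 nM.
Compound 2 `CC(C)c1onc(-c2c(Cl)cccc2Cl)c1COc1ccc(-c2nc3ccc(C(=O)O)cc3n2CC2CCCCC2)cc1` — in this assay compound 2 gives 0.52 nM.

Among the compounds with values here, compound 2 has the lowest of the two numbers; the only other measured value lies one step away: a 3.5-fold lower number from compound 1 to compound 2 (0.54 log units; beyond the scatter). Compound 3 `CC(=O)C1CCC(Cn2c(-c3ccc(OCc4c(-c5c(Cl)cccc5Cl)noc4C(C)C)cc3)nc3ccc(C(=O)O)cc32)CC1` differs from compound 2 in one place: acetyl in place of hydrogen on a saturated ring carbon. Within the data shown here, the single measured step exchanged the whole group on that aromatic nitrogen and was modest in size; no measured step adds a group onto the ring itself. The change from compound 2 to compound 3 is therefore expected to be small, a 1.5-fold higher number from compound 2 to compound 3 (0.19 log units; within the scatter), in either direction. Compound 3 is estimated at 0.8 nM in this assay, between 0.25 nM and 3 nM.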

Compound 3, half-maximal effective concentration: 1170 nM
Estimate against measurement, compound 3: 1500-fold (3.17 log units) below, and the stated range ends below it.
By their numbers in this assay, from the lowest: compound 2; then compound 1; then compound 3.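

The ring on the aromatic nitrogen does not tolerate every addition: placing acetyl on a saturated ring carbon, three ring bonds from the ring atom that bears a large group, gives a 2300-fold higher number from compound 2 to compound 3 (3.35 log units; beyond the scatter) in this assay. The step of a 650-fold higher number from compound 1 to compound 3 (2.81 log units; beyond the scatter) is also large, whereas the exchange of 1-propylbutyl for cyclohexylmethyl was modest. No measurement here explains this jump.

As far as these compounds go, it remains open whether any added group at this ring carbon has this effect or whether it is specific to acetyl. A methyl, a hydroxyl or an amine at the same place could help tell these apart.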